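The compounds below may be only part of what the source reports. "The series", "measured", "known", "first", "only" and "open" are said of these compounds alone.

The measured compounds:

Compound 1, `CCc1nnc(O)n2c(C(C)(C)C)nc(C)c12`, gives 26000 nM in a functional assay for inhibition, with Homo sapiens as the target; a higher number here means a weaker inhibitor, a lower number a stronger inhibitor.

Compound 2, `CCc1nc(C)c2c(-c3ccccc3)nnc(O)n12`, gives only a limit in this assay: > 48000 nM.

Compound 2 thus stands at a limit of the assay rather than at a number, as the limit of > 48000 nM in this assay, at which 1 of the 2 values shown sits, records. Compound 3, `CCc1nnc(O)n2c(CC)nc(C)c12`, is not yet measured. It differs from compound 2 in one place: ethyl in place of phenyl on an aromatic carbon. Among the compounds with values here, no step between measured compounds covers this change, so the expectation rests only on what the two measured values show: compound 1 sits at a number, while compound 2 sits at a limit, and the two are not far apart. Compound 3 is expected to come in at a number close to what is already seen, which would mean a step of an at least 1.6-fold lower number from compound 2 to compound 3 (0.20 log units; that floor lies within the scatter). The estimate for compound 3 in this assay is 30000 nM, with a range from 10000 nM to 100000 nM.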

Compound 3, half-maximal inhibitory concentration: 24000 nM
Compound 3: middle estimate off by 1.3-fold (0.10 log units), on the high side; low and high end bracket the measured number.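

In this assay, ethyl and tert-butyl on this aromatic carbon cannot be told apart, with a 1.1-fold lower number from compound 1 to compound 3 (0.03 log units; within the scatter). Putting ethyl in place of phenyl gives an at least 2.0-fold lower number from compound 2 to compound 3 (0.30 log units; that floor lies within the scatter), so this change has no exact size, and whether it goes beyond the scatter stays undecided. Compound 2, the phenyl compound, gives only a limit and not a number: the limit of > 48000 nM in this assay, at which 1 of the 3 values shown sits.

On these data alone, whether a primary amine, a carboxylic acid or a longer chain such as n-hexyl on this aromatic carbon would move the number remains open. Also open, as far as these compounds go, is what changes elsewhere on the shared core would do, for example an amine in place of the hydroxy group.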